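Amide nitrogen substituent in a Bcl-2 binding series

A few compounds are considered here, and "the series" means these few. Any claim that something is new, unique, unknown or untested is made for them only; others in the source may bear on it.

Three compounds share one core and differ only in what sits on the amide-type nitrogen. Compound 3 `CC(C)=CCCC1=CC[C@H](C(=O)NO)[C@@H](c2ccccc2)C1` carries a hydroxy there, and in an assay on isolated protein for inhibition of Apoptosis regulator Bcl-2 (Homo sapiens), read by fluorescence polarization, with stated times of 5 min and 10 min (a higher number here means a weaker inhibitor, a lower number a stronger inhibitor), compound 3 gives 600 nM, the lowest of the two numbers reported. Compound 1 `CC(C)=CCCC1=CC[C@H](C(=O)N(C)O)[C@@H](c2ccccc2)C1` adds a methyl to that nitrogen, and in this assay compound 1 gives 2100 nM. Compound 2 `CC(C)=CCCC1=CC[C@H](C(=O)NCCC(=O)O)[C@@H](c2ccccc2)C1` carries a 2-carboxyethyl instead of the hydroxy, and in this assay compound 2 reaches only a limit of the assay, > 23000 nM. Removing the methyl gave a 3.5-fold lower number from compound 1 to compound 3 (0.54 log units; beyond the scatter), while restoring the hydroxy in place of the 2-carboxyethyl gave an at least 38-fold lower number from compound 2 to compound 3 (1.58 log units; beyond the scatter); one value here is a limit, (the limit of > 23000 nM in this assay, at which 1 of the 3 values shown sits).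

Compound 4 `COc1ccc(NC(=O)[C@H]2CC=C(CCC=C(C)C)C[C@@H]2c2ccccc2)cc1` changes the same position: 4-methoxyphenyl in place of hydroxy on an amide-type nitrogen. Both steps at this nitrogen bear on it, and both show that losing the hydroxy or adding a methyl there raises the number. A step upward in this assay beyond the scatter is therefore expected, of a size comparable to the larger of the two steps at this nitrogen, as a 15-fold higher number from compound 3 to compound 4 (1.18 log units; beyond the scatter). In this assay compound 4 is expected to give about 9000 nM, within a range of 2000 nM to 30000 nM.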

Compound 4, inhibition constant: > 23000 nM
Compound 4: only a limit was reported (the forecaster's own chance of this, stated with the estimate: 35%); middle value at least 2.5-fold (0.40 log units) away from the limit.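

The change to 4-methoxyphenyl gives an at least 38-fold higher number from compound 3 to compound 4 (1.58 log units; beyond the scatter), so the rise in the number is not confined to the chain ending in a carboxylic acid in compound 2. The hydroxy(methyl)amino group of compound 1 also sits well clear of this aryl amide, with an at least 10-fold higher number from compound 1 to compound 4 (1.03 log units; beyond the scatter), and so, among the compounds shown, a hydroxy on this nitrogen goes with the lower numbers whether or not the methyl is present. In this assay compound 4 gives only a limit, > 23000 nM, and compound 2 stops at the same limit, so the step between these two cannot be read: the limit of > 23000 nM in this assay, at which 2 of the 4 values shown sit.

On these data alone, both compounds without the hydroxy sit at that limit, so how far either lies beyond it remains unknown, and an aryl group cannot be ranked against the acid chain at this nitrogen. As far as these compounds go, it also remains open whether the hydroxy itself is required or whether a small group such as methoxy, an amino group or a plain methyl on this nitrogen would keep the number near that of compound 3.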